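The source may report more compounds than this note shows. Statements on the series, on what has been measured and on what is new or still open speak of the compounds shown alone.

Measured compounds:
Compound 1 `CCCCc1cn(C[C@H](O)[C@H]2OC(=O)C(OCc3ccccc3)=C2OCc2ccccc2)nn1` in a functional assay on HCT-116 cells (Homo sapiens) for antiproliferative activity, read by MTT assay, with a stated time of 72 h (a higher number here means a weaker inhibitor, a lower number a stronger inhibitor), gives 10400 nM.
Compound 2 `O=C1O[C@H]([C@@H](O)Cn2cc(CCCCl)nn2)C(OCc2ccccc2)=C1OCc1ccccc1` gives 36100 nM.
Compound 3 `Cc1ccc(S(=O)(=O)NCc2cn(C[C@H](O)[C@H]3OC(=O)C(OCc4ccccc4)=C3OCc3ccccc3)nn2)cc1` gives 13100 nM.

Compound 3 holds the second highest of the three numbers. Its nearest neighbour is compound 1, with a 1.3-fold higher number from compound 1 to compound 3 (0.10 log units; within the scatter), a gap that stays within the scatter; its furthest is compound 2, with a 2.8-fold lower number from compound 2 to compound 3 (0.44 log units; beyond the scatter), a modest gap beyond it. Compound 4 `O=C1O[C@H]([C@@H](O)Cn2cc(CNS(=O)(=O)c3ccc(Cl)cc3F)nn2)C(OCc2ccccc2)=C1OCc1ccccc1` differs from compound 3 by 4-chloro-2-fluorophenyl in place of 4-methylphenyl on a sulfonyl sulfur.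

Among the measured compounds shown here, none of the measured steps alters the aryl group on the sulfonyl sulfur, so no step bears directly on this change. All three steps act at the saturated chain carbon bound to the aromatic carbon of the triazole: a 3.5-fold higher number from compound 1 to compound 2 (0.54 log units; beyond the scatter), a 1.3-fold higher number from compound 1 to compound 3 (0.10 log units; within the scatter) and a 2.8-fold lower number from compound 2 to compound 3 (0.44 log units; beyond the scatter). Even quite different groups there shift this assay by no more than a modest amount, and the whole series sits in a narrow window. An exchange of one aryl ring for another, one bond further from the core than the sulfonyl, is therefore expected to move the number little, most likely within the scatter, in either direction.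

Compound 4 is estimated at 13000 nM, with a range of 5000 nM to 35000 nM. The expected step is a 1.0-fold lower number from compound 3 to compound 4 (0.00 log units; within the scatter).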

Compound 4, half-maximal inhibitory concentration: 21600 nM
For compound 4 the middle estimate is 1.7-fold (0.22 log units) below the measured one, within the range that was stated.
By their numbers in this assay, from the lowest: compounds 1, 3, 4 and 2 (each within the scatter of the next, the first and the last beyond it).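

In this assay, among the compounds shown here, the first measured exchange at the aryl group on the sulfonyl sulfur, 4-chloro-2-fluorophenyl in place of 4-methylphenyl, gives a 1.6-fold higher number from compound 3 to compound 4 (0.22 log units; within the scatter) and so does not separate the two sulfonamides beyond the scatter. The exchange still alters how the sulfonamide compares with the chloro chain: a 2.8-fold lower number from compound 2 to compound 3 (0.44 log units; beyond the scatter) lay beyond the scatter, whereas a 1.7-fold lower number from compound 2 to compound 4 (0.22 log units; within the scatter) lies within it. The comparison with the butyl compound shifts the opposite way, from a 1.3-fold higher number from compound 1 to compound 3 (0.10 log units; within the scatter) to a 2.1-fold higher number from compound 1 to compound 4 (0.32 log units; beyond the scatter), which is a modest gap beyond the scatter, so a within-scatter aryl exchange is enough to alter how these sulfonamides rank against the simple chains.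

No measurement on hand explains these numbers. Since chloro and fluoro enter together, the compounds shown leave open what each contributes alone, as in 4-chlorophenyl or 2-fluorophenyl on the sulfonyl sulfur, and also how a ring carrying a carboxylic acid or an amine, or a plain methyl in place of the aryl ring, would read in this assay.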